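Chloro to dimethylamino at the weak end of the series

A few compounds are considered here, and "the series" means these few. Any claim that something is new, unique, unknown or untested is made for them only; others in the source may bear on it.

Measured in a functional assay on MT4 cells (Homo sapiens) for inhibition; a lower number here means a stronger inhibitor, a higher number a weaker inhibitor:
- compound 1 `C=C1C(n2ccc(N)nc2=O)O[C@H](CO)[C@@H]1O`: 190 nM
- compound 2 `C=C1[C@@H](O)[C@H](n2cnc3c(S)nc(N)nc32)O[C@@H]1CO`: 12000 nM
- compound 3 `C=C1[C@H](n2cnc3c(Cl)nc(N)nc32)O[C@H](CO)[C@H]1O`: 176000 nM

Compound 3 carries the highest number of the three and is the weakest inhibitor here, with its gaps to compound 2 and compound 1 both beyond the scatter. Compound 4 `C=C1[C@H](n2cnc3c(N(C)C)nc(N)nc32)O[C@H](CO)[C@H]1O` has dimethylamino in place of chloro on an aromatic carbon.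

Within the data shown here, no measured pair isolates this change, so any expectation rests on a thin basis. Compound 2, which has no chloro, gives 12000 nM, and this is the nearest value on the lower side of compound 3. A moderate step towards a lower number in this assay is therefore expected, although a step within the scatter cannot be excluded. The expected change is a 2.9-fold lower number from compound 3 to compound 4 (0.47 log units; beyond the scatter). For compound 4 the estimated value is 60000 nM, with an expected range of 10000 nM to 250000 nM.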

Compound 4, half-maximal inhibitory concentration: > 500000 nM
Compound 4: only a limit was reported (the forecaster's own chance of this, stated with the estimate: 25%); middle value at least 8.3-fold (0.92 log units) from the limit.
By their numbers in this assay, from the lowest: compound 1; then compound 2; then compound 3. At a limit, above all of these: compound 4.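

In this assay compound 4 gives > 500000 nM, which is a limit and not a number. Dimethylamino in place of chloro on the aromatic carbon next to the ring nitrogen gives an at least 2.8-fold higher number from compound 3 to compound 4 (0.45 log units; beyond the scatter), the first step in the series that isolates a single change at this position, and it runs towards weaker inhibition rather than towards a lower number. The size of this step is known only as a bound, and the reading rests on one censored value: the limit of > 500000 nM in this assay, at which 1 of the 4 values shown sits.

The compounds shown leave open how far compound 4 lies beyond its limit, so the full size of the loss stays unknown. They also leave open whether a smaller group at this place, such as methylamino or methoxy, would move the number in the same direction.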